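Expected Solubility After a Naphthalen-1-yl Replacement

This account rests on a few compounds, and the source may have more. Where it says the series, first, only, none or still open, it means among the compounds named here.

Of the compounds shown here, two sharing one core have been measured in a physicochemical assay for solubility, with a stated time of 18 h, at pH 7.4; a lower number here means a less soluble compound, a higher number a more soluble compound. Compound 1 `COc1cccc(Oc2ccc3c(NCCCNCc4cc(F)ccc4OC)ccnc3c2)c1` gives 14500 nM. In this assay compound 2 `COc1ccc(F)cc1CNCCCNc1ccnc2cc(Cc3ccc(F)cc3Cl)ccc12` gives 4200 nM, the lowest of the two numbers. Going by the values given here, the only measured step, a 3.5-fold lower number from compound 1 to compound 2 (0.54 log units; beyond the scatter), came with 2-chloro-4-fluorobenzyl in place of 3-methoxyphenoxy on an aromatic carbon. Compound 3 `COc1ccc(F)cc1CNCCCNc1ccnc2cc(-c3cccc4ccccc34)ccc12` has not yet been measured; it differs from compound 2 by a single change: naphthalen-1-yl in place of 2-chloro-4-fluorobenzyl on an aromatic carbon. No measured step involves naphthalen-1-yl, so the one step shown, a 3.5-fold lower number from compound 1 to compound 2 (0.54 log units; beyond the scatter), bears on it only as a guide to how far a change at this aromatic carbon has moved the number so far, and in that case the direction was downward. Compound 3 is therefore expected to come out at 2000 nM, with a range from 500 nM to 8000 nM. That expectation corresponds to a step of a 2.1-fold lower number from compound 2 to compound 3 (0.32 log units; beyond the scatter).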

Compound 3, solubility: 32000 nM
The estimate for compound 3 lay 16-fold (1.20 log units) below the measured number; measured number outside the range, above it.
By their numbers in this assay, from the lowest: compound 2; then compound 1; then compound 3.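

In this assay, this aromatic carbon proved able to carry the number upward as well as downward: naphthalen-1-yl in place of 2-chloro-4-fluorobenzyl gave a 7.6-fold higher number from compound 2 to compound 3 (0.88 log units; beyond the scatter). Naphthalen-1-yl in place of 3-methoxyphenoxy gave a 2.2-fold higher number from compound 1 to compound 3 (0.34 log units; beyond the scatter), so of the three groups shown here, the highest number belongs to the one with two six-membered aromatic rings of carbon only. Nothing available here accounts for this rise.

Three groups at one carbon cannot show whether the number would hold or fall with an amine or a carboxylic acid there. As far as these compounds go, it also remains open whether naphthalen-1-yl would give a step of similar size with a longer chain between the two nitrogens of the shared core.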